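The compounds below may be only part of what the source reports. "The series", "measured", "known", "first", "only" and "open" are said of these compounds alone.

Measured compounds in an assay on isolated protein with Bile acid receptor (Homo sapiens) as the target; a higher number here means that more compound is needed for the effect, a lower number that less compound is needed:
- compound 1 `COC(=O)/C=C/c1cccc(N(Cc2ccc(/C=C/c3c(Cl)cccc3Cl)cc2)C(=O)C(C)C)c1`: 195 nM
- compound 2 `COC(=O)/C=C/c1cccc(N(Cc2ccc(/C=C/c3ccccn3)cc2)C(=O)C(C)C)c1`: 310 nM
- compound 3 `COC(=O)/C=C/c1cccc(N(Cc2ccc(/C=C/c3scnc3C)cc2)C(=O)C(C)C)c1`: 228 nM

Compound 3 stands second highest of the three numbers in this assay. Its nearest neighbour is compound 1, with a 1.2-fold higher number from compound 1 to compound 3 (0.07 log units; within the scatter), and its furthest is compound 2, with a 1.4-fold lower number from compound 2 to compound 3 (0.13 log units; within the scatter); both gaps are within the scatter, so the three compounds cannot be ordered on these data.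

Compound 4 `CCOc1cccc(-c2ccc(CN(C(=O)C(C)C)c3cccc(/C=C/C(=O)OC)c3)cc2)c1` differs from compound 3 in one place: 3-ethoxyphenyl in place of 2-(4-methyl-1,3-thiazol-5-yl)ethenyl on an aromatic carbon. The measured steps all exchange the ring at the end of the double-bonded chain while keeping that chain, and each of them, a 1.6-fold higher number from compound 1 to compound 2 (0.20 log units; within the scatter), a 1.2-fold higher number from compound 1 to compound 3 (0.07 log units; within the scatter) and a 1.4-fold lower number from compound 2 to compound 3 (0.13 log units; within the scatter), lies within the scatter. None of them removes the double-bonded chain or places a ring directly on the aromatic carbon, so they bear on the new change only loosely: they show that the terminal ring itself hardly matters here, but they say nothing about the chain. A step in this assay that stays within the scatter, or a modest move in either direction, is the most that these data support.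

Compound 4 is therefore expected to give about 300 nM, with a range from 110 nM to 850 nM. The step this estimate implies is expected to be a 1.3-fold higher number from compound 3 to compound 4 (0.12 log units; within the scatter).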

Compound 4, half-maximal effective concentration: 173 nM
Compound 4: the middle estimate sits 1.7-fold (0.24 log units) above what was measured; measured number inside the range.
By their numbers in this assay, from the lowest: compounds 4, 1, 3 and 2 (each within the scatter of the next).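

In this assay, taking out the double-bonded chain and placing 3-ethoxyphenyl directly on the aromatic carbon, para to a large group, gives steps within the scatter against all three earlier compounds: a 1.3-fold lower number from compound 3 to compound 4 (0.12 log units; within the scatter), a 1.8-fold lower number from compound 2 to compound 4 (0.25 log units; within the scatter) and a 1.1-fold lower number from compound 1 to compound 4 (0.05 log units; within the scatter). The earlier compounds had shown only that the ring at the end of the chain could be exchanged with the chain kept, whereas compound 4 shows that the ethenyl link can also go without a step beyond the scatter, at least when this carbon-only ring enters. Nothing available here gives a reason for this result.

From the compounds shown here alone, the step to compound 4 changes the chain and the terminal ring together, so what each contributes on its own stays open. Going by these compounds, it is also open whether steps at this position would stay within the scatter with a carboxylic acid or an amine on the directly attached ring in place of the ethoxy group, or with a longer chain there.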